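A Lactam Replaces the Amide on the Piperidine

This account rests on a few compounds, and the source may have more. Where it says the series, first, only, none or still open, it means among the compounds named here.

Going by the values given here, compound 2 `COCC(=O)NC1CCN(c2nc(C)c3cc(NC(=O)/C=C/c4ccc(OC(F)(F)F)cc4)ccc3n2)CC1` gives 14 nM in a functional assay on CHO-K1 cells for antagonist activity at melanin-concentrating hormone receptor 1 (Homo sapiens), read by inositol phosphate accumulation, with stated times of 10 min and 45 min (a higher number here means a weaker inhibitor, a lower number a stronger inhibitor), the lower of the two numbers known, while compound 1 `C/C(=C\C(=O)Nc1ccc2nc(N3CCC(O)(C4CC4)CC3)nc(C)c2c1)c1ccc(Cl)cc1` gives 340 nM in this assay, a gap beyond the scatter. Compound 3 `Cc1nc(N2CCC(N3CCCC3=O)CC2)nc2ccc(NC(=O)/C=C/c3ccc(OC(F)(F)F)cc3)cc12` differs from compound 2 by 2-oxopyrrolidin-1-yl in place of ((methoxymethyl)carbonyl)amino on a saturated ring carbon. Among the compounds with values here, no measured pair shows this change, so compound 3 is expected to show a step of a 1.8-fold higher number from compound 2 to compound 3 (0.25 log units; within the scatter) that stays within or only slightly beyond the scatter, leaning toward a higher number. Compound 3 is estimated at 25 nM in this assay, with a range from 8 nM to 80 nM.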

Compound 3, half-maximal inhibitory concentration: 12 nM
Compound 3: the middle estimate sits 2.1-fold (0.32 log units) above what was measured; measured number inside the range.
By their numbers in this assay, from the lowest: compounds 3 and 2 (each within the scatter of the next); then compound 1.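

At this saturated ring carbon, 2-oxopyrrolidin-1-yl replaces ((methoxymethyl)carbonyl)amino in this assay with a 1.2-fold lower number from compound 2 to compound 3 (0.07 log units; within the scatter). The position therefore tolerates a five-membered non-aromatic ring with no hydrogen-bond donor as well as the open chain of compound 2, which has one, so in this pair that donor is not required. Nothing available explains why the two groups match. From the compounds shown here alone, it remains open whether a six-membered lactam, an amine or a carboxylic acid at this ring carbon would keep the activity.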